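Swapping the aryl acid arm on a stable plasma scaffold

A few compounds are considered here, and "the series" means these few. Any claim that something is new, unique, unknown or untested is made for them only; others in the source may bear on it.

Compound 3 `Cc1cc(OCCCCOc2ccc(C(=O)CC3CCCC3)c(O)c2C)ccc1C(=O)O` was tested in an ADME assay on a cell-free system (plasma, Rattus norvegicus) for metabolic stability, read by LC-MS, with a stated time of 60 min, tested at 100 uM (on this read-out higher numbers stand for a more stable compound and lower numbers for a less stable compound), and gives 114%. Among the three measured compounds it stands second highest; compound 1 `Cc1c(OCCCCOc2ccc(C(=O)O)cc2Cl)ccc(C(=O)CC2CCCC2)c1O` gives 120%, and compound 2 `CCCC(=O)c1ccc(OCCCCOc2cc(C(=O)O)ccc2OC)c(C)c1O` gives 78%, the latter beyond the scatter from compound 3. Within the data shown here, the one measured step that changes the aryl group on the oxygen on the saturated carbon, a number 6 percentage points lower from compound 1 to compound 3 (within the scatter), lies within the scatter. Compound 4 `COc1ccc(C(=O)O)cc1OCCCCOc1ccc(C(=O)CC2CCCC2)c(O)c1C` differs from compound 3 in the same place: 5-carboxy-2-methoxyphenyl in place of 4-carboxy-3-methylphenyl on an oxygen on a saturated carbon. The entering group is the same aryl acid that compound 2 carries, but compound 2 also differs from compound 4 at the ketone, so its lower value cannot be read as a step. Taking the within-scatter step from compound 1 to compound 3 as the closer guide, while allowing for the lower value of compound 2, the expected change is a number 14 percentage points lower from compound 3 to compound 4 (beyond the scatter), a modest drop. Compound 4 is therefore estimated at 100%, within the range 72% to 125%.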

Compound 4, percent of the compound remaining: 103%
Estimate against measurement, compound 4: 3 percentage points below; low and high end bracket the measured number.
By their numbers in this assay, from the lowest: compound 2; then compound 4; then compounds 3 and 1 (each within the scatter of the next).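

In this assay the aryl group on the oxygen on a saturated carbon now shows that it can move the number: 5-carboxy-2-methoxyphenyl comes with a number 11 percentage points lower from compound 3 to compound 4 (beyond the scatter) and a number 17 percentage points lower from compound 1 to compound 4 (beyond the scatter). Between the two other aryl acids there is a number 6 percentage points lower from compound 1 to compound 3 (within the scatter). With that aryl acid held fixed, the ketone side also matters, as cyclopentyl in place of ethyl on a saturated chain carbon bound to a carbonyl carbon gives a number 25 percentage points higher from compound 2 to compound 4 (beyond the scatter) in the same read-out. No measurement available here accounts for either change.

On these data alone, whether the lower number of compound 4 goes with the methoxy group or with where the carboxylic acid sits on the ring stays open. Also open, as far as these compounds go, is how a tetrazole in place of the carboxylic acid, or a longer chain between the two oxygens, would read.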